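From Bromine to Phenyl at a Sensitive Position

The source may report more compounds than this note shows. Statements on the series, on what has been measured and on what is new or still open speak of the compounds shown alone.

Of the compounds shown here, three sharing one core have been measured in a functional assay on the whole organism (integument) for inhibition, with Chilo suppressalis as the target, read by scintillation counting, with a stated time of 72 h; a lower number here means a stronger inhibitor, a higher number a weaker inhibitor. Compound 1 `COc1cccc(OC)c1C(=O)Nc1nnc(-c2ccc(C)cc2)s1` gives 1230 nM. Compound 2 `COc1cccc(OC)c1C(=O)Nc1nnc(-c2ccc(F)cc2)s1` gives 97.7 nM, and compound 3 `COc1cccc(OC)c1C(=O)Nc1nnc(-c2ccc(Br)cc2)s1` gives 66.1 nM. Compound 3 therefore has the lowest number of the three, although a 1.5-fold lower number from compound 2 to compound 3 (0.17 log units; within the scatter), so these two cannot be ranked against each other; by contrast a 19-fold lower number from compound 1 to compound 3 (1.27 log units; beyond the scatter). The measured steps show that the group at this carbon matters: a 13-fold lower number from compound 1 to compound 2 (1.10 log units; beyond the scatter) and a 19-fold lower number from compound 1 to compound 3 (1.27 log units; beyond the scatter), whereas a 1.5-fold lower number from compound 2 to compound 3 (0.17 log units; within the scatter).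

Compound 4 `COc1cccc(OC)c1C(=O)Nc1nnc(-c2ccc(-c3ccccc3)cc2)s1` carries yet another group at the same carbon: phenyl in place of bromo on an aromatic carbon. Among the compounds with values here, no measured step involves a phenyl here; the steps only show that exchanging the group at this carbon can shift the number greatly, as from methyl to a halogen, or hardly at all, as from fluoro to bromo. The direction of the new step cannot be read from them, so the uncertainty is wide. The number for compound 4 in this assay is estimated at 250 nM, with a range from 60 nM to 1200 nM. This estimate means an expected step of a 3.8-fold higher number from compound 3 to compound 4 (0.58 log units; beyond the scatter), a modest rise held with low confidence.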

Compound 4, half-maximal inhibitory concentration: 195 nM
Compound 4: middle estimate off by 1.3-fold (0.11 log units), on the high side; low and high end bracket the measured number.
By their numbers in this assay, from the lowest: compounds 3, 2 and 4 (each within the scatter of the next, the first and the last beyond it); then compound 1.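

In this assay this carbon accepts much more than a single atom: phenyl, with 6 heavy atoms and a ring of its own, replaces bromo, with 1 heavy atom, at the price of only a modest rise (a 3.0-fold higher number from compound 3 to compound 4 (0.47 log units; beyond the scatter)). Compared with the fluoro compound, the phenyl compound cannot be told apart (a 2.0-fold higher number from compound 2 to compound 4 (0.30 log units; within the scatter)), yet it stays clearly better than the methyl compound (a 6.3-fold lower number from compound 1 to compound 4 (0.80 log units; beyond the scatter)), so among these four compounds the number does not simply climb as the group grows, and compound 1 with its methyl is the one that goes against such a trend. No measurement at hand explains why methyl does so much worse than these other groups.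

Going by these compounds, what would happen with an amine, a carboxylic acid or a longer chain at this carbon stays open, so it is unclear how far the tolerance seen for phenyl extends. On these data alone, all four compounds also share the rest of the core, so it remains unknown whether the same order would hold if another part of the molecule were changed, or if the added phenyl ring carried a chloro or methoxy group of its own.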